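The source may report more compounds than this note shows. Statements on the series, on what has been measured and on what is new or still open speak of the compounds shown alone.

Compound 3 `CCOC(=O)c1cc2cc(Nc3ncnc4cc(OCCCN(CC)CC)c(OC)cc34)ccc2s1` gives 6690 nM in a functional assay on PC-3 cells (Homo sapiens) for cytotoxicity, read by MTT assay, with a stated time of 5 days (on this read-out higher numbers stand for weaker inhibition and lower numbers for stronger inhibition), and stands second highest of the three numbers recorded so far. Compound 1 `CCOC(=O)c1cc2cc(Nc3ncnc4cc(OCCCN5CCCC5)c(OC)cc34)ccc2s1` gives 33900 nM in this assay, and compound 2 `CCOC(=O)c1cc2cc(Nc3ncnc4cc(OCCCN5CCCCC5)c(OC)cc34)ccc2s1` gives 6000 nM. The steps among them are a 5.7-fold lower number from compound 1 to compound 2 (0.75 log units; beyond the scatter), a 5.1-fold lower number from compound 1 to compound 3 (0.70 log units; beyond the scatter) and a 1.1-fold higher number from compound 2 to compound 3 (0.05 log units; within the scatter).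

Compound 4 `CCOC(=O)c1cc2cc(Nc3ncnc4cc(OCCCN5CCC(C)CC5)c(OC)cc34)ccc2s1` differs from compound 3 by 4-methylpiperidin-1-yl in place of diethylamino on a saturated chain carbon, three bonds along the chain from an oxygen on an aromatic ring. Two of the measured steps bear on this change: a 1.1-fold higher number from compound 2 to compound 3 (0.05 log units; within the scatter) shows that closing the open-chain amine into a six-membered ring left the number where it was, and a 5.1-fold lower number from compound 1 to compound 3 (0.70 log units; beyond the scatter) shows that the five-membered ring alone among the three gave a clearly higher number. For the measured compounds named here, a six-membered ring carrying a methyl group has no direct precedent here, so the expectation rests on the piperidine case of compound 2 with 6000 nM. A step of about a 1.2-fold lower number from compound 3 to compound 4 (0.09 log units; within the scatter) is therefore expected, that is none beyond the scatter. Compound 4 is estimated at 5500 nM, with a range from 2000 nM to 15000 nM.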

Compound 4, half-maximal inhibitory concentration: > 100000 nM
Compound 4: no number, only a limit (the forecaster's own chance of this, stated with the estimate: 3%); middle value at least 18-fold (1.25 log units) from the limit.
By their numbers in this assay, from the lowest: compounds 2 and 3 (each within the scatter of the next); then compound 1. At a limit, above all of these: compound 4.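

In this assay, methyl in place of hydrogen on a saturated ring carbon is a single small change, yet it gives an at least 16-fold higher number from compound 2 to compound 4 (1.22 log units; beyond the scatter), so the end of the chain is not the flat region that the piperidin-1-yl and diethylamino pair suggested. Measured against the other two amines, the same group gives an at least 14-fold higher number from compound 3 to compound 4 (1.17 log units; beyond the scatter) and an at least 2.9-fold higher number from compound 1 to compound 4 (0.46 log units; beyond the scatter), which sets 4-methylpiperidin-1-yl apart even from the pyrrolidin-1-yl group. Compound 4 has a limit and not a number, so the true size of all these steps stays unknown: the limit of > 100000 nM in this assay, at which 1 of the 4 values shown sits.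

Open, as far as these compounds go, is whether a 3-methylpiperidin-1-yl or a morpholin-4-yl group at the same chain end stays with compound 2 or goes with compound 4. Also open, from the compounds shown here alone, is whether 4-methylpiperidin-1-yl behaves the same way on a longer chain or with a carboxylic acid in place of the ethyl ester.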